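Adding a third methoxy group to the pendant aryl ring

The source may report more compounds than this note shows. Statements on the series, on what has been measured and on what is new or still open speak of the compounds shown alone.

Compound 1, `Cc1cc(O)c(C2=NN(c3ccc(S(N)(=O)=O)cc3)C(c3ccccc3Cl)C2)cc1Cl`, gives 63600 nM in a functional assay on SNB-75 cells (Homo sapiens) for antiproliferative activity, with a stated time of 48 h; on this read-out higher numbers stand for lower toxicity in this test and lower numbers for higher toxicity in this test. Compound 2, `Cc1cc(O)c(C2=NN(c3ccc(S(N)(=O)=O)cc3)C(/C=C/c3ccccc3)C2)cc1Cl`, gives 44400 nM in this assay. Compound 3, `COc1ccc(C2CC(c3cc(Cl)c(C)cc3O)=NN2c2ccc(S(N)(=O)=O)cc2)cc1OC`, reaches only the limit of this assay, > 100000 nM, so no number is known for it.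

Compound 3 thus stands at the limit of > 100000 nM in this assay, at which 1 of the 3 values shown sits, with an at least 1.5-fold higher number from compound 1 to compound 3 (0.19 log units; that floor lies within the scatter) and an at least 2.2-fold higher number from compound 2 to compound 3 (0.35 log units; beyond the scatter). Compound 4, `COc1ccc(C2CC(c3cc(Cl)c(C)cc3O)=NN2c2ccc(S(N)(=O)=O)cc2)c(OC)c1OC`, differs from compound 3 in one place: methoxy in place of hydrogen on an aromatic carbon. Among the compounds with values here, no measured step tests this change on its own; the two steps onto compound 3 only show that compound 3 already sits at the limit. Compound 4 is therefore expected to stay near that limit, with a step that the limit leaves unreadable from compound 3 to compound 4, and its value in this assay is estimated at 110000 nM, within 50000 nM to 250000 nM.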

Compound 4, concentration lethal to 50% of the cells: > 100000 nM
Compound 4 gave a limit, no number; the forecaster's own chance of this, stated with the estimate: 70%; the middle value does not contradict the limit.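

Compound 4 also ends at a limit of this assay, not at a number, so the added methoxy group leaves the read-out at the top of the range: the limit of > 100000 nM in this assay, at which 2 of the 4 values shown sit. The step between compound 3 and compound 4 cannot be read. The 2,3,4-trimethoxyphenyl group gives an at least 2.2-fold higher number from compound 2 to compound 4 (0.35 log units; beyond the scatter) and an at least 1.5-fold higher number from compound 1 to compound 4 (0.19 log units; that floor lies within the scatter).

From the compounds shown here alone, it stays open whether this methoxy group changes anything on a pendant ring that gives a number, such as 2-chlorophenyl. Going by these compounds, it also stays open whether an amine or a carboxylic acid at this position would bring the value within range.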